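This account rests on a few compounds, and the source may have more. Where it says the series, first, only, none or still open, it means among the compounds named here.

Three sulfonamides built on one shared core have been examined in a functional assay on HepG2 cells for inhibition of squalene monooxygenase (Homo sapiens); on this read-out higher numbers stand for weaker inhibition and lower numbers for stronger inhibition. Compound 1 `CCN(C/C=C/C#CC(C)(C)C)Cc1cccc(OCCN(C)S(=O)(=O)c2ccsc2)c1` gives 250 nM, compound 2 `CCN(C/C=C/C#CC(C)(C)C)Cc1cccc(OCCN(C)S(=O)(=O)c2ccc(Br)cc2)c1` gives 330 nM, and compound 3 `CCN(C/C=C/C#CC(C)(C)C)Cc1cccc(OCCN(C)S(=O)(=O)c2cccnc2)c1` gives 150 nM in this assay. Compound 3 thus carries the lowest number of the three, although its separation from compound 1 stays within the scatter, a 1.7-fold lower number from compound 1 to compound 3 (0.22 log units; within the scatter); its separation from compound 2 is larger, a 2.2-fold lower number from compound 2 to compound 3 (0.34 log units; beyond the scatter), whereas a 1.3-fold higher number from compound 1 to compound 2 (0.12 log units; within the scatter).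

The unmeasured compound 4 `CCN(C/C=C/C#CC(C)(C)C)Cc1cccc(OCCN(C)S(=O)(=O)c2ccc(Br)s2)c1` differs from compound 3 in one place: 5-bromothiophen-2-yl in place of pyridin-3-yl on a sulfonyl sulfur. Among the compounds with values here, two measured steps bear on this change. Going from thiophen-3-yl to pyridin-3-yl lowered the number only within the scatter, and going from 4-bromophenyl to pyridin-3-yl lowered it modestly. Compound 4 undoes the pyridine and brings in both a thiophene and a bromine, so a return toward the numbers of compound 1 and compound 2 is expected. That expectation amounts to a 1.9-fold higher number from compound 3 to compound 4 (0.27 log units; within the scatter). Compound 4 is therefore estimated at 280 nM, with a range from 150 nM to 550 nM.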

Compound 4, half-maximal inhibitory concentration: 390 nM
The estimate for compound 4 lay 1.4-fold (0.14 log units) below the measured number; measured number inside the range.
By their numbers in this assay, from the lowest: compounds 3, 1, 2 and 4 (each within the scatter of the next, the first and the last beyond it).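

In this assay, the step of a 2.6-fold higher number from compound 3 to compound 4 (0.41 log units; beyond the scatter) places 5-bromothiophen-2-yl on the sulfonyl sulfur beyond the scatter from pyridin-3-yl, so both bromine-bearing groups, in compound 2 and compound 4, now stand apart from compound 3, while compound 1 stays within the scatter of it. The five-membered bromine-bearing ring adds no separation from the six-membered one or from the plain thiophene, as the step of a 1.2-fold higher number from compound 2 to compound 4 (0.07 log units; within the scatter) and the step of a 1.6-fold higher number from compound 1 to compound 4 (0.19 log units; within the scatter) both lie within the scatter. With these compounds, the bromine and the point of attachment of the thiophene cannot be told apart, and thiophen-2-yl would speak to that. Going by these compounds, whether a methyl group or a cyclohexyl ring on the sulfonyl sulfur would give similar numbers also remains open. No measurement on hand accounts for these differences.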